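Hydroxy Added to the Methoxyphenyl Imine of Compound 2

The source may report more compounds than this note shows. Statements on the series, on what has been measured and on what is new or still open speak of the compounds shown alone.

Compound 1 `Cc1c(/N=C/c2ccccc2Cl)c(=O)n(-c2ccccc2)n1C` gives 324000000 nM in a functional assay on P388 cells (Mus musculus) for cytotoxicity, read by MTT assay, with a stated time of 72 h; a lower number here means a stronger inhibitor, a higher number a weaker inhibitor. For the measured compounds named here, compound 2 `COc1cccc(/C=N/c2c(C)n(C)n(-c3ccccc3)c2=O)c1` gives 105000000 nM in this assay, the lower of the two numbers, and the sole measured step is a 3.1-fold lower number from compound 1 to compound 2 (0.49 log units; beyond the scatter). Compound 3 `COc1cccc(/C=N/c2c(C)n(C)n(-c3ccccc3)c2=O)c1O` differs from compound 2 by hydroxy in place of hydrogen on an aromatic carbon. That one step exchanged the whole aryl group; it does not bear directly on adding a hydroxy, so no measured guide exists for this change. The author therefore expects a step of a 1.2-fold lower number from compound 2 to compound 3 (0.09 log units; within the scatter), not beyond the scatter. Compound 3 is estimated at 85000000 nM, with a range from 30000000 nM to 250000000 nM.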

Compound 3, half-maximal inhibitory concentration: 851000000 nM
Compound 3: middle estimate off by 10-fold (1.00 log units), on the low side, and the stated range ends below it.
By their numbers in this assay, from the lowest: compound 2; then compound 1; then compound 3.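

In this assay, hydroxy in place of hydrogen on this aromatic carbon, ortho to a large group and ortho to a methoxy group, is not a neutral change: the record shows an 8.1-fold higher number from compound 2 to compound 3 (0.91 log units; beyond the scatter). For the compounds shown here, the earlier step exchanged the whole aryl group, so this is the first reading of one added group at this place, and it runs toward a weaker inhibitor. No measured finding accounts for this step. Going by these compounds, whether this belongs to hydroxy itself or to any group on this carbon stays open. An amine or a chlorine atom here could separate the two.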